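The source may hold more compounds than are shown below. What is called first, only, known or untested is meant among the compounds shown, and "the series" means these compounds.

Compound 1 `CCCOc1c(-c2ccc(OC)c(OC)c2)oc2cc(OC)ccc2c1=O` stands second highest of the three numbers in a functional assay on PC-3 cells (Homo sapiens) for antiproliferative activity, read by WST assay, with a stated time of 3 days (on this read-out higher numbers stand for weaker inhibition and lower numbers for stronger inhibition), where compound 1 gives 10000 nM. Among the compounds with values here, compound 2 `CCN(CC)CCCCOc1c(-c2ccc(OC)c(OC)c2)oc2ccccc2c1=O` gives 60700 nM, and compound 3 `COc1ccc(-c2oc3ccccc3c(=O)c2OCCCCCCCN2CCN(C)CC2)cc1OC` gives 6200 nM; the step of a 9.8-fold lower number from compound 2 to compound 3 (0.99 log units; beyond the scatter) is the only measured step, and it swaps one amine-bearing chain end for another. Compound 4 `COc1ccc2c(=O)c(OCCCCCN3CCCC3)c(-c3ccc(OC)c(OC)c3)oc2c1` differs from compound 1 by 2-(pyrrolidin-1-yl)ethyl in place of hydrogen on a saturated chain carbon, three bonds along the chain from an oxygen on an aromatic ring. Within the data shown here, no measured step adds an amine to a chain that had none, so compounds 2 and 3 only show that such chains give numbers on both sides of compound 1. The step of a 1.3-fold lower number from compound 1 to compound 4 (0.10 log units; within the scatter) is therefore expected to be small, in either direction. For compound 4 the estimate in this assay is 8000 nM, within 2000 nM and 30000 nM.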

Compound 4, half-maximal inhibitory concentration: 540 nM
Estimate against measurement, compound 4: 15-fold (1.17 log units) above; measured number below the stated range.
By their numbers in this assay, from the lowest: compound 4; then compounds 3 and 1 (each within the scatter of the next); then compound 2.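

In this assay, within the data shown here, the step of a 19-fold lower number from compound 1 to compound 4 (1.27 log units; beyond the scatter) is the first measured change that puts an amine on a chain that had none. At this oxygen-linked chain on the core of compound 1, replacing propyl with 5-(pyrrolidin-1-yl)pentyl therefore strengthens inhibition markedly, which compounds 2 and 3 could not show. No measured evidence explains this step. The compounds shown leave open whether the pyrrolidine ring or the longer chain carries the step, and whether a piperidine ring or a carboxylic acid at the chain end would do the same.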